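Three thiophene-ring analogues and a pyrazole newcomer

A few compounds are considered here, and "the series" means these few. Any claim that something is new, unique, unknown or untested is made for them only; others in the source may bear on it.

Measured so far in an assay on CHO cells for displacement of a labelled ligand from adenosine receptor A1 (Homo sapiens), read by scintillation counting, tested at 10 uM; on this read-out lower numbers stand for less inhibition and higher numbers for more inhibition at the one concentration tested (going by the name of the read-out):
- Compound 1, `CC(C)(C)Cc1c(-c2ccccn2)sc(N)c1C(=O)c1ccc(Cl)cc1`, gives 1%.
- Compound 2, `Cc1ccc(-c2sc(N)c(C(=O)c3ccc(Cl)cc3)c2CC(C)(C)C)cc1`, gives 1%.
- Compound 3, `CC(C)(C)Cc1c(Br)sc(N)c1C(=O)c1ccc(Cl)cc1`, gives 1%.

Compound 3 stands level with compounds 1 and 2 at the digits shown, since the step of no change at the digits printed from compound 1 to compound 3 (within the scatter) and the step of no change at the digits printed from compound 2 to compound 3 (within the scatter) both stay within the scatter, as does the step of no change at the digits printed from compound 1 to compound 2 (within the scatter). Swapping the group on that ring carbon among pyridin-2-yl, 4-methylphenyl and bromo thus left the read-out unmoved throughout.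

Compound 4, `CC(C)(C)Cc1c(-c2cn[nH]c2)sc(N)c1C(=O)c1ccc(Cl)cc1`, has not yet been measured. It differs from compound 3 in one place: 1H-pyrazol-4-yl in place of bromo on an aromatic carbon. The three measured steps all bear on this position, and all were flat, so the data give no sign that a change at this ring carbon moves the read-out in this assay at all.

On that basis the step of a number 1 percentage points higher from compound 3 to compound 4 (within the scatter) is expected to stay within the scatter. Compound 4 is therefore estimated at 2%, with a range from -6% to 12%.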

Compound 4, a percentage reported as inhibition, at one concentration (the size of the read-out at that concentration, not a potency): 1%
Compound 4: the middle estimate sits 1 percentage points above what was measured; the range from low to high includes it.
By their numbers in this assay, from the lowest: compounds 1, 2, 3 and 4 (each within the scatter of the next).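

Placing 1H-pyrazol-4-yl on this ring carbon adds a five-membered aromatic ring with a hydrogen-bond donor and a hydrogen-bond acceptor, neither of which bromo has, yet this assay shows the step of no change at the digits printed from compound 3 to compound 4 (within the scatter). The comparisons with the two earlier ring substituents agree, with the step of no change at the digits printed from compound 2 to compound 4 (within the scatter) and the step of no change at the digits printed from compound 1 to compound 4 (within the scatter). The flat picture at this position therefore now extends to a group with a ring nitrogen carrying a hydrogen, and no available evidence accounts for this result.

As far as these compounds go, whether an amine or a carboxylic acid on this ring carbon would move the read-out remains open. So does whether a shorter chain in place of the neopentyl group, which all four compounds share, would change the read-out.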